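This account rests on a few compounds, and the source may have more. Where it says the series, first, only, none or still open, it means among the compounds named here.

Three compounds have been measured in an in vitro assay on BTI-TN-5B1-4 cells for inhibition of Amine oxidase [flavin-containing] A (Homo sapiens), read by fluorescence, with a stated time of 15 min, tested at 100 uM; a lower number here means less inhibition, a higher number more inhibition at the concentration tested (going by the name of the read-out):

Compound 1 `Clc1ccc(/C=N/Nc2nc(-c3ccc(Cl)cc3)cs2)cc1`: 40%
Compound 2 `COc1ccc(/C=N/Nc2nc(-c3ccc(Cl)cc3)cs2)cc1OC`: 40%
Compound 3 `COc1ccc(/C=N/Nc2nc(-c3ccc(F)cc3)cs2)cc1`: 40%

Compound 3 stands level with compound 1 and compound 2 at the digits shown, the nearest being compound 1 and the furthest compound 2, with both gaps inside the usual scatter. Compound 4 `COc1ccc(/C=N/Nc2nc(-c3ccc(Cl)cc3)cs2)cc1` has not yet been measured. It differs from compound 3 in one place: chloro in place of fluoro on an aromatic carbon. Among the compounds with values here, no pair among the measured compounds differs in only one place, so no measured step guides this change. The step from compound 3 to compound 4 is therefore expected to be small, no change at the digits printed from compound 3 to compound 4 (within the scatter), none beyond the scatter. Compound 4 is estimated at 40%, between 25% and 55%.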

Compound 4, a percentage reported as inhibition, at one concentration (the size of the read-out at that concentration, not a potency): 40%
Estimate against measurement, compound 4: no gap at the digits printed, within the range that was stated.
By their numbers in this assay, from the lowest: compounds 1, 2, 3 and 4 (each within the scatter of the next).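

Chloro in place of fluoro on this aromatic carbon, the change from 4-fluorophenyl to 4-chlorophenyl, gives no change at the digits printed from compound 3 to compound 4 (within the scatter) in this assay and so offers the first direct reading at this position. Compound 4 also provides single-place comparisons elsewhere: hydrogen in place of methoxy gives no change at the digits printed from compound 2 to compound 4 (within the scatter) and methoxy in place of chloro gives no change at the digits printed from compound 1 to compound 4 (within the scatter) on an aromatic carbon. Nothing available explains why these changes leave the reading level. As far as these compounds go, whether an amine or a carboxylic acid at this position would shift the reading remains open.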